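The source may report more compounds than this note shows. Statements on the series, on what has been measured and on what is new or still open speak of the compounds shown alone.

- compound 1 `CC(C)(C)C[C@@H](O)C(=O)N1[C@@H]2C[C@@H]2C[C@H]1C(=O)NCc1cc(Cl)ccc1-n1cnnn1` gives 71 mL.min-1.g-1
- compound 2 `CC(C)(C)C[C@@H](O)C(=O)N1[C@H](C(=O)NCc2cc(Cl)ccc2-n2cnnn2)C[C@@H]2C[C@@H]21` gives 40 mL.min-1.g-1

Among the measured compounds shown here, in an ADME assay on liver for metabolic stability, with Liver microsome (Homo sapiens) as the target, read by LC-MS, using microsomes (a lower number here means slower removal, a higher number faster removal of the compound), compound 1 and compound 2 cannot be told apart once the usual scatter of repeated measurements is allowed for, with a 1.8-fold lower number from compound 1 to compound 2 (0.25 log units; within the scatter) as the only step. That step comes with the fact that compounds 1 and 2 differ only in the configuration as drawn and leaves the chain untouched, so it gives no direct measure of a change in the chain.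

Compound 3 `CCCC[C@@H](O)C(=O)N1[C@@H]2C[C@@H]2C[C@H]1C(=O)NCc1cc(Cl)ccc1-n1cnnn1` has not yet been measured. Its difference from compound 1 is propyl in place of tert-butyl on a saturated chain carbon, two bonds along the chain from a carbonyl carbon and an oxygen on a saturated carbon and in words it is propyl in place of tert-butyl on a saturated chain carbon, two bonds along the chain from a carbonyl carbon and an oxygen on a saturated carbon. Cut one bond further out, the same difference reads neopentyl to butyl.

For the measured compounds named here, no measured step covers a change of this kind, so the starting point is compound 1 at 71 mL.min-1.g-1 and no shift beyond the scatter is expected in either direction. The expected change is a 1.2-fold lower number from compound 1 to compound 3 (0.07 log units; within the scatter) in this estimate. Compound 3 is expected at 60 mL.min-1.g-1 with an estimated range of 25 mL.min-1.g-1 to 130 mL.min-1.g-1 in this assay's units.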

Compound 3, intrinsic clearance in microsomes: 89 mL.min-1.g-1
Compound 3: the middle estimate sits 1.5-fold (0.17 log units) below what was measured; the measured number falls inside the stated range.
By their numbers in this assay, from the lowest: compounds 2, 1 and 3 (each within the scatter of the next, the first and the last beyond it).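

In this assay, the change at this position, propyl in place of tert-butyl on a saturated chain carbon, two bonds along the chain from a carbonyl carbon and an oxygen on a saturated carbon, gives a 1.3-fold higher number from compound 1 to compound 3 (0.10 log units; within the scatter). This is the only step shown that alters the chain, and it gives a first direct reading: for this one pair, a neopentyl end and a butyl end cannot be told apart in this assay, so this single swap gives no sign that the chain's shape at this position matters for the number. The data shown offer no explanation for this result, as the one fact available concerns configuration and not the chain.

From the compounds shown here alone, one swap says little about the position as a whole, so it remains open whether a longer chain such as hexyl, or a chain ending in an amine or a carboxylic acid, would also stay within the scatter of compound 1. Going by these compounds, it also remains open whether the same change from tert-butyl to propyl would read the same way on compound 2, whose configuration differs.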